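A few compounds are considered here, and "the series" means these few. Any claim that something is new, unique, unknown or untested is made for them only; others in the source may bear on it.

Working notes, an assay on isolated protein for inhibition of DNA nucleotidylexotransferase (Homo sapiens), read by scintillation counting, with a stated time of 10 min; on this read-out higher numbers stand for weaker inhibition and lower numbers for stronger inhibition. Compound 3 `CCOC(=O)C(=O)CC(=O)/C=C/c1cc(C(=O)c2ccccc2)cn1Cc1ccc(C#N)cc1` in this assay gives only a limit, > 40 uM. Compound 2 `CCOC(=O)C(=O)CC(=O)/C=C/c1cc(C(=O)c2ccccc2)cn1Cc1ccc(F)cc1` likewise returns a limit in this assay, > 40 uM. For the measured compounds named here, the single measured step, a step that the two limits leave unreadable from compound 2 to compound 3, is therefore not readable, both ends sitting at the limit of > 40 uM in this assay, at which 2 of the 3 values shown sit. Going by the values given here, compound 1 `O=C(/C=C/c1cn(CC(=O)N2CCOCC2)c2ccccc12)CC(=O)C(=O)O` carries a carboxy group and in this assay gives 24 uM; no step from compound 1 to compound 3 is computed, so the two numbers are only set side by side.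

Compound 4 `N#Cc1ccc(Cn2cc(C(=O)c3ccccc3)cc2/C=C/C(=O)CC(=O)C(=O)O)cc1` differs from compound 3 by hydrogen in place of ethyl on an oxygen next to a carbonyl group. Among the compounds with values here, no measured step covers this change. The two ethyl esters, compound 2 and compound 3, do not give a readable number in this assay. Compound 4 is nevertheless expected to give a readable number, with a step estimated at an at least 2.0-fold lower number from compound 3 to compound 4 (0.30 log units; that floor lies within the scatter), because compound 1, which carries the same carboxy group, gives 24 uM in this assay. The estimate for compound 4 in this assay is 20 uM, with a range from 5 uM to 40 uM.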

Compound 4, concentration for 50% inhibition: 6.8 uM
Estimate against measurement, compound 4: 2.9-fold (0.47 log units) above; low and high end bracket the measured number.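

In this assay, the change from ethoxycarbonyl to carboxy gives the series its first readable step at this position: an at least 5.8-fold lower number from compound 3 to compound 4 (0.76 log units; beyond the scatter). Within the pair of compound 3 and compound 4, the ethyl on this oxygen is therefore not tolerated as well as hydrogen, a difference that the ethyl esters alone could not show, and the step from compound 2 to compound 3 still cannot be read. The true size of the new step stays open because compound 3 gives only a limit, so the printed size is a floor: the limit of > 40 uM in this assay, at which 2 of the 4 values shown sit.

From the compounds shown here alone, it remains open whether the same step holds with fluoro in place of cyano on the aromatic carbon, as in compound 2. Going by these compounds, it is also open whether a methyl, a longer chain or an amine in place of the hydroxy of the carboxy group would read closer to compound 3 or to compound 4.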